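Aryl for alkyl on the imidazole side chain

The source may hold more compounds than are shown below. What is called first, only, known or untested is meant among the compounds shown, and "the series" means these compounds.

Measured compounds:
compound 1, `O=C(O)c1ccccc1-c1ccc(CCc2ncc(CC3CCC3)[nH]2)cc1`: 588 nM
compound 2, `CCCCc1cnc(CCc2ccc(-c3ccccc3C(=O)O)cc2)[nH]1`: 2710 nM

Two compounds share a core and differ only in the group on a saturated chain carbon bound to an aromatic carbon. In an in vitro functional assay on cells for agonist activity at Bombesin receptor subtype-3 (Homo sapiens), read by luminescence and calcium flux (a higher number here means that more compound is needed for the effect, a lower number that less compound is needed), compound 1 gives 588 nM, and compound 2 gives 2710 nM, the highest of the two numbers. Going by the values given here, the one measured step, a 4.6-fold higher number from compound 1 to compound 2 (0.66 log units; beyond the scatter), shows that replacing the ring-bearing group by the open propyl chain raised the number beyond the scatter.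

Compound 3, `COc1ccccc1Cc1cnc(CCc2ccc(-c3ccccc3C(=O)O)cc2)[nH]1`, has not yet been measured. It differs from compound 2 in one place: 2-methoxyphenyl in place of propyl on a saturated chain carbon bound to an aromatic carbon

Among the compounds with values here, the only step that bears on this change is a 4.6-fold higher number from compound 1 to compound 2 (0.66 log units; beyond the scatter), which showed that a group with a ring on this carbon carried a lower number than propyl. Compound 3 again brings a ring onto this carbon, though an aromatic one carrying a hydrogen-bond acceptor rather than the cyclobutyl of compound 1, so the direction is estimated as a lower number and its size is uncertain. The estimate for compound 3 is 900 nM, within 200 nM to 4500 nM, which as a step is expected to read a 3.0-fold lower number from compound 2 to compound 3 (0.48 log units; beyond the scatter).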

Compound 3, half-maximal effective concentration: 1720 nM
Compound 3: middle estimate off by 1.9-fold (0.28 log units), on the low side; the measured number falls inside the stated range.
By their numbers in this assay, from the lowest: compound 1; then compounds 3 and 2 (each within the scatter of the next).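

In this assay, putting 2-methoxyphenyl in place of propyl on this saturated chain carbon gives a 1.6-fold lower number from compound 2 to compound 3 (0.20 log units; within the scatter), so the two groups cannot be told apart here, even though the entering group is much the larger, with a six-membered aromatic ring and a hydrogen-bond acceptor that propyl lacks. A ring on this carbon therefore does not by itself go with the low number of compound 1: set against cyclobutyl, the same 2-methoxyphenyl group gives a 2.9-fold higher number from compound 1 to compound 3 (0.47 log units; beyond the scatter), and compound 1 keeps the lowest number of the three, with its steps to both others beyond the scatter. No measurement at hand offers an explanation for this difference between the cyclobutyl ring and the aromatic ring.

On these data alone, what a plain phenyl would read on this carbon stays open, and with it whether the methoxy group or the aromatic ring itself decides where compound 3 stands. Equally open, as far as these compounds go, is whether the low number of compound 1 is particular to cyclobutyl or would extend to other saturated rings such as cyclopentyl or cyclohexyl.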